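From 2-methylphenyl to 4-methylphenyl in compound 4

The source may report more compounds than this note shows. Statements on the series, on what has been measured and on what is new or still open speak of the compounds shown alone.

Values so far in a functional assay on DU-145 cells (Homo sapiens) for inhibition, read by MTT assay, with a stated time of 72 h; on this read-out higher numbers stand for weaker inhibition and lower numbers for stronger inhibition
compound 1 `O=C(O)CCCCCCC(=O)Nc1ccc(C2=C(c3ccc(O)cc3)C3CC(S(=O)(=O)Oc4ccccc4C(F)(F)F)C2O3)cc1` gives > 100000 nM
compound 2 `O=C(O)CCCCCCC(=O)Nc1ccc(C2=C(c3ccc(O)cc3)C3CC(S(=O)(=O)Oc4cccc5ccccc45)C2O3)cc1` gives 48600 nM
compound 3 `Cc1ccccc1OS(=O)(=O)C1CC2OC1C(c1ccc(NC(=O)CCCCCCC(=O)O)cc1)=C2c1ccc(O)cc1` gives > 100000 nM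

Compound 3 gives > 100000 nM as a limit of the assay and not a number. Compound 1 gives > 100000 nM as a limit too. These two make up the limit of > 100000 nM in this assay, at which 2 of the 3 values shown sit, and only compound 2 has a true number.

Compound 4 `Cc1ccc(OS(=O)(=O)C2CC3OC2C(c2ccc(NC(=O)CCCCCCC(=O)O)cc2)=C3c2ccc(O)cc2)cc1` carries 4-methylphenyl in place of 2-methylphenyl on an oxygen, and the count reads 4-methylphenyl in place of 2-methylphenyl on an oxygen as its full difference.

Within the data shown here, no measured step moves a methyl group, so the evidence is indirect. Naphthalen-1-yl in place of 2-(trifluoromethyl)phenyl gave an at least 2.0-fold lower number from compound 1 to compound 2 (0.31 log units; beyond the scatter) and 2-methylphenyl in place of naphthalen-1-yl gave an at least 2.0-fold higher number from compound 2 to compound 3 (0.31 log units; beyond the scatter) in turn. Methyl in place of trifluoromethyl gave a step that the two limits leave unreadable from compound 1 to compound 3 and so tells nothing about size. Compound 4 keeps a single six-membered aromatic ring, like compound 3 with its limit of > 100000 nM and weak inhibition is therefore expected to persist, with no firm direction. The expected change is an at least 1.1-fold lower number from compound 3 to compound 4 (0.04 log units; that floor lies within the scatter) and it may well prove unreadable.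

For compound 4 the estimated value is 90000 nM with an expected range from 35000 nM to 200000 nM.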

Compound 4, half-maximal inhibitory concentration: 80800 nM
Beside the measured number, compound 4's estimate is 1.1-fold (0.05 log units) above it, and the stated range covers the measured number.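

In this assay the 4-methylphenyl of compound 4 gives a true number where the 2-methylphenyl of compound 3 gives none, and the change reads as an at least 1.2-fold lower number from compound 3 to compound 4 (0.09 log units; that floor lies within the scatter). A single six-membered aromatic ring on this oxygen can therefore give a number that cannot be told apart from that of the naphthalen-1-yl, with a 1.7-fold higher number from compound 2 to compound 4 (0.22 log units; within the scatter), while the change from 2-(trifluoromethyl)phenyl reads as an at least 1.2-fold lower number from compound 1 to compound 4 (0.09 log units; that floor lies within the scatter). Compound 1 and compound 3 remain limits of the assay, not numbers: the limit of > 100000 nM in this assay, at which 2 of the 4 values shown sit.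

From the compounds shown here alone, whether the methyl group matters at all stays open, and a plain phenyl or a 4-methoxyphenyl on this oxygen would test that. Also open, going by these compounds, is whether a 3-methylphenyl or a 4-chlorophenyl would behave like 4-methylphenyl or fall back to the limit.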